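The compounds below may be only part of what the source reports. "The series", "measured", "known", "first", "only" and "open" are said of these compounds alone.

Measured in an assay on HEK293 cells for inhibition of acid ceramidase (Homo sapiens), read by fluorescence, with stated times of 10 min and 3 h; a lower number here means a stronger inhibitor, a higher number a weaker inhibitor:

- compound 1 `CCOCCNC(=O)n1c(=O)oc2cc(C3CCN(C)CC3)ccc21`: 1050 nM
- compound 2 `CC(C)CNC(=O)n1c(=O)oc2cc(C3CCN(C)CC3)ccc21`: 166 nM
- compound 3 `CN1CCC(c2ccc3c(c2)oc(=O)n3C(=O)NCCCCc2ccccc2)CC1`: 129 nM

Compound 3 holds the lowest of the three numbers in this assay, but its gap to compound 2, a 1.3-fold lower number from compound 2 to compound 3 (0.11 log units; within the scatter), is within the scatter, so the two cannot be ordered; only compound 1 sits clearly apart, with an 8.1-fold lower number from compound 1 to compound 3 (0.91 log units; beyond the scatter).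

Compound 4 `CCCCCNC(=O)n1c(=O)oc2cc(C3CCN(C)CC3)ccc21` is the next member. It differs from compound 3 by methyl in place of phenyl on a saturated chain carbon, four bonds along the chain from an amide-type nitrogen; the chain itself is kept, so the carbamoyl substituent becomes a plain pentyl in place of the 4-phenylbutyl.

Going by the values given here, two measured steps bear on this. The step of a 1.3-fold lower number from compound 2 to compound 3 (0.11 log units; within the scatter), from a branched alkyl to the phenyl-bearing chain, stayed within the scatter, which suggests the terminal phenyl contributes little on its own. The step of an 8.1-fold lower number from compound 1 to compound 3 (0.91 log units; beyond the scatter) was larger, but it also removed an ether oxygen from the chain, which compound 4 does not do. Taken together, the expectation for this assay is a small step, if any, probably toward a slightly higher number, a 1.6-fold higher number from compound 3 to compound 4 (0.19 log units; within the scatter).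

Compound 4 is therefore estimated at 200 nM, with a range of 80 nM to 500 nM.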

Compound 4, half-maximal inhibitory concentration: 396 nM
Beside the measured number, compound 4's estimate is 2.0-fold (0.30 log units) below it, and the stated range covers the measured number.
By their numbers in this assay, from the lowest: compounds 3 and 2 (each within the scatter of the next); then compound 4; then compound 1.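

In this assay, going by these compounds alone, cutting the phenyl back to methyl on a saturated chain carbon, four bonds along the chain from an amide-type nitrogen, gives a 3.1-fold higher number from compound 3 to compound 4 (0.49 log units; beyond the scatter), so this single change moves the number beyond the scatter, which the earlier steps could not show on their own. The phenyl is not the only thing that matters, however: butyl in place of isopropyl on the saturated chain carbon bound to the amide-type nitrogen gives a 2.4-fold higher number from compound 2 to compound 4 (0.38 log units; beyond the scatter), and compound 2 carries no phenyl yet stays within the scatter of compound 3, so it goes against any rule that the phenyl is required for the lower numbers. Propyl in place of ethoxy, two bonds along the chain from the amide-type nitrogen, gives a 2.7-fold lower number from compound 1 to compound 4 (0.42 log units; beyond the scatter), which shows that a step beyond the scatter remains at this part of the chain with no phenyl on either side.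

Still open, going by these compounds, is how a longer chain, or an amine or a carboxylic acid in place of the phenyl at this chain carbon, would compare with compound 3. Nothing at hand gives a reason for any of these steps.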